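This account rests on a few compounds, and the source may have more. Where it says the series, first, only, none or still open, it means among the compounds named here.

Compound 1 `Cc1cc2cc(NS(=O)(=O)c3ccc([N+](=O)[O-])cc3)ccc2[nH]1` and compound 2 `Cc1cc2cc(NS(=O)(=O)c3ccc(F)cc3)ccc2[nH]1` share one core and differ in a single place: fluoro in place of nitro on an aromatic carbon. In an ADME assay on J774 cells (Mus musculus) for cytotoxicity, read by fluorescence and resazurin assay, with a stated time of 24 h (a higher number here means that more compound is tolerated, a lower number that less compound is tolerated), compound 1 gives 132000 nM, and compound 2 gives 40400 nM; the difference is a 3.3-fold lower number from compound 1 to compound 2 (0.51 log units; beyond the scatter). Compound 3 `O=[N+]([O-])c1ccc(S(=O)(=O)Nc2ccc3[nH]ncc3c2)cc1` carries the same nitro group on a different core; the difference between the two cores is not broken down here. In this assay compound 3 gives 133000 nM, a value that lies with compound 1 within the scatter. Compound 4 `O=S(=O)(Nc1ccc2[nH]ncc2c1)c1ccc(F)cc1` has not been measured and differs from compound 3 only by fluoro in place of nitro on an aromatic carbon, the same change as between compound 1 and compound 2. Going by the values given here, the earlier step of a 3.3-fold lower number from compound 1 to compound 2 (0.51 log units; beyond the scatter) is the only guide available. A step of similar size is expected in this assay, a 3.3-fold lower number from compound 3 to compound 4 (0.52 log units; beyond the scatter). For compound 4 the expected value in this assay is 40000 nM, estimated to fall between 20000 nM and 80000 nM.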

Compound 4, half-maximal cytotoxic concentration: >= 300000 nM
Compound 4: only a limit was reported (the forecaster's own chance of this, stated with the estimate: 5%); at least 7.5-fold (0.87 log units) between middle value and limit.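

In this assay, the change from nitro to fluoro gives an at least 2.2-fold higher number from compound 3 to compound 4 (0.35 log units; beyond the scatter), so the step seen on the core of compound 1 does not carry over to the core of compound 3, and the two steps run in opposite directions: the same change on two cores in this assay, a 3.3-fold lower number (0.51 log units; beyond the scatter) from compound 1 to compound 2 and an at least 2.2-fold higher number (0.35 log units; beyond the scatter) from compound 3 to compound 4, at least 7.3-fold (0.86 log units) apart, beyond the scatter of two such steps

Compound 4 has only a limit of the assay, >= 300000 nM, and not an exact number. The true size of the new step therefore stays unknown, and these two pairs cannot show why the two cores respond differently.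

The compounds shown leave open whether a third core would follow either pattern. They also leave open how an amine or a carboxylic acid in the same place would behave on each core.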